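A Ring Swap on Compound 1, Ahead of Its Measurement

The source may report more compounds than this note shows. Statements on the series, on what has been measured and on what is new or still open speak of the compounds shown alone.

Compound 1 `Cn1c(=O)c(S(=O)(=O)c2ccc(F)cc2F)cc2cnc(Nc3ccc4sccc4c3)nc21` gives 500 nM in a functional assay on DU-145 cells (Homo sapiens) for inhibition, read by trypan blue exclusion, with a stated time of 72 h; a lower number here means a stronger inhibitor, a higher number a weaker inhibitor. Compound 2 `CCn1c(=O)c(S(=O)(=O)c2ccc(F)cc2F)cc2cnc(Nc3ccc4[nH]ccc4c3)nc21` gives 750 nM, so compound 1 holds the lower of the two numbers, but the two lie within the scatter of each other. Compound 3 `Cn1c(=O)c(S(=O)(=O)c2ccc(F)cc2F)cc2cnc(Nc3ccc4c(c3)C(=O)C(=O)N4)nc21` is not yet measured. It differs from compound 1 as follows: a group of 11 heavy atoms (8 carbon, 1 nitrogen, 2 oxygen; one five-membered non-aromatic ring with 1 hetero atom, one six-membered aromatic ring of carbon only) in place of a group of 9 heavy atoms (8 carbon, 1 sulfur; one five-membered aromatic ring with 1 hetero atom, one six-membered aromatic ring of carbon only), on a nitrogen on an aromatic ring. Going by the values given here, no step between measured compounds covers this change, so the expected step of a 1.6-fold higher number from compound 1 to compound 3 (0.20 log units; within the scatter) is a modest one, with a small loss more likely than a gain. Compound 3 is therefore estimated at 800 nM, within 250 nM to 2500 nM.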

Compound 3, half-maximal inhibitory concentration: 75000 nM
Beside the measured number, compound 3's estimate is 94-fold (1.97 log units) below it, outside the stated range (above it).
By their numbers in this assay, from the lowest: compounds 1 and 2 (each within the scatter of the next); then compound 3.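

In this assay, the place on a nitrogen on an aromatic ring proves highly sensitive to what it carries: replacing 1-benzothiophen-5-yl with the group holding a five-membered non-aromatic ring gives a 150-fold higher number from compound 1 to compound 3 (2.18 log units; beyond the scatter) in this single change. No earlier step had shown how much this place can matter. Nothing measured here explains the loss.

Which part of the entering group matters remains open. So does whether a plain phenyl ring, or one carrying an amine or a carboxylic acid, would keep the number near that of compound 1.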